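Benzyloxycarbonyl to Benzoyl in a Hydroxamic Acid Series

The compounds below may be only part of what the source reports. "The series", "measured", "known", "first", "only" and "open" are said of these compounds alone.

Compound 1, `O=C(CCCSC[C@H](NC(=O)OCc1ccccc1)C(=O)Nc1ccccc1)NO`: > 200 nM
Compound 2, `O=C(CCCSC[C@H](NC(=O)OCc1ccccc1)C(=O)Nc1cccc2ccccc12)NO`: > 200 nM

In an assay on isolated protein for inhibition of histone deacetylase 5 (Homo sapiens), read by fluorescence, with a stated time of 1 h (a lower number here means a stronger inhibitor, a higher number a weaker inhibitor), compound 1 gives > 200 nM, which is a limit of the assay and not a number. Compound 2 likewise gives > 200 nM in this assay, again a limit. The change with naphthalen-1-yl in place of phenyl on an amide-type nitrogen therefore yields a step that the two limits leave unreadable from compound 1 to compound 2. Both shown values rest at the limit of > 200 nM in this assay, at which 2 of the 2 values shown sit, so compound 1 stands only at a limit, with no measured value that places it within the readable range.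

Compound 3, `O=C(CCCSC[C@H](NC(=O)c1ccccc1)C(=O)Nc1ccccc1)NO`, differs from compound 1 by phenyl in place of benzyloxy on a carbonyl carbon. Among the compounds with values here, no measured step touches this position, so nothing measured bears on its size. With compound 1 known only as a limit, compound 3 is expected to show a step that the limit leaves unreadable from compound 1 to compound 3, which in practice means a value most probably still at or beyond that limit. The estimate for compound 3 in this assay is 400 nM, within a range from 150 nM to 3000 nM.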

Compound 3, half-maximal inhibitory concentration: > 200 nM
Compound 3: no number, only a limit; the forecaster's own chance of this, stated with the estimate: 65%; the middle value is on the limit's open side.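

In this assay compound 3 gives > 200 nM, a limit of the assay and not a number. No step from compound 1 to compound 3 can therefore be read: the limit of > 200 nM in this assay, at which 3 of the 3 values shown sit.

The compounds shown leave open whether phenyl in place of benzyloxy changes inhibition at all.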